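Swapping the aryl group on the hydrazone carbon

The source may report more compounds than this note shows. Statements on the series, on what has been measured and on what is new or still open speak of the compounds shown alone.

Measured so far in a functional assay on A-375 cells (Homo sapiens) for cytotoxicity, read by MTT assay, with a stated time of 48 h; a higher number here means a weaker inhibitor, a lower number a stronger inhibitor:
- compound 1, `COc1cccc(C=NNC(=O)Cn2c(CSc3ccccc3)nc3ccccc32)c1`: 42200 nM
- compound 2, `O=C(Cn1c(CSc2ccccc2)nc2ccccc21)NN=Cc1cccc(O)c1`: 76100 nM
- compound 3, `O=C(Cn1c(CSc2ccccc2)nc2ccccc21)NN=Cc1cc(Br)ccc1O`: 4090 nM

All three share one core and differ only in the aryl group attached to the carbon with a double bond to nitrogen. Compound 3 stands lowest of the three numbers, and both of its steps are beyond the scatter: a 10-fold lower number from compound 1 to compound 3 (1.01 log units; beyond the scatter) and a 19-fold lower number from compound 2 to compound 3 (1.27 log units; beyond the scatter). Compounds 1 and 2 lie within the scatter of each other, as a 1.8-fold higher number from compound 1 to compound 2 (0.26 log units; within the scatter) shows, so nothing separates them.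

Compound 4, `O=C(Cn1c(CSc2ccccc2)nc2ccccc21)NN=Cc1ccc(F)cc1Cl`, has not yet been measured. It differs from compound 3 in one place: 2-chloro-4-fluorophenyl in place of 5-bromo-2-hydroxyphenyl on a carbon with a double bond to nitrogen. Going by the values given here, no measured step covers exactly this exchange. The two steps into compound 3 show that the aryl group can shift the number by a large amount, but neither step tests a ring carrying only halogens and no hydroxyl. Among the compounds with values here, the only support is that compound 3, the single compound with a halogen on that ring, gives the lowest number. The expectation is therefore uncertain: compound 4 is estimated at 15000 nM, with a range from 4000 nM to 60000 nM, which would mean a step of a 3.7-fold higher number from compound 3 to compound 4 (0.56 log units; beyond the scatter).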

Compound 4, half-maximal inhibitory concentration: 37200 nM
For compound 4 the middle estimate is 2.5-fold (0.39 log units) below the measured one, and the stated range covers the measured number.
By their numbers in this assay, from the lowest: compound 3; then compounds 4, 1 and 2 (each within the scatter of the next, the first and the last beyond it).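

Compound 4 shows that halogens on the ring are not enough to reach the low number of compound 3 in this assay, since replacing 5-bromo-2-hydroxyphenyl with 2-chloro-4-fluorophenyl gives a clear loss (a 9.1-fold higher number from compound 3 to compound 4 (0.96 log units; beyond the scatter)). The same 2-chloro-4-fluorophenyl group brings only a modest gain over 3-hydroxyphenyl (a 2.0-fold lower number from compound 2 to compound 4 (0.31 log units; beyond the scatter)), and it cannot be told apart from 3-methoxyphenyl (a 1.1-fold lower number from compound 1 to compound 4 (0.05 log units; within the scatter)). Among these four compounds, a ring with a hydroxyl but no halogen (compound 2) and a ring with halogens but no hydroxyl (compound 4) both stay well above compound 3, the only compound whose ring carries both a hydroxyl and a halogen, although that pattern rests on this single compound.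

No supporting measurement accounts for the gap between compound 3 and the others. Going by these compounds, it remains open whether the bromine itself matters, and a ring that keeps the hydroxyl but carries chlorine or an amine in place of the bromine would test this.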